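The source may report more compounds than this note shows. Statements on the series, on what has been measured and on what is new or still open speak of the compounds shown alone.

Measured compounds:
Compound 1, `Cc1ncnc2c1c(-c1cc3ccccc3o1)cn2[C@@H]1O[C@H](CO)[C@@H](O)[C@H]1O`: > 20000 nM
Compound 2, `Cc1nc(N)c2c(-c3cc4ccccc4o3)cn([C@@H]3O[C@H](CO)[C@@H](O)[C@H]3O)c2n1`: > 20000 nM
Compound 3, `Cc1ncnc2c1c(-c1ccsc1)cn2[C@@H]1O[C@H](CO)[C@@H](O)[C@H]1O`: 460 nM

The study follows three nucleoside-like compounds in a functional assay on HCT-116 cells (Homo sapiens), read by MTT assay, with a stated time of 72 h; on this read-out higher numbers stand for weaker inhibition and lower numbers for stronger inhibition. Compound 1 `Cc1ncnc2c1c(-c1cc3ccccc3o1)cn2[C@@H]1O[C@H](CO)[C@@H](O)[C@H]1O` reaches only the limit of the assay, and in this assay compound 1 gives > 20000 nM, which is a limit rather than a number. Compound 2 `Cc1nc(N)c2c(-c3cc4ccccc4o3)cn([C@@H]3O[C@H](CO)[C@@H](O)[C@H]3O)c2n1` likewise sits at the limit, giving > 20000 nM in this assay. Compound 3 `Cc1ncnc2c1c(-c1ccsc1)cn2[C@@H]1O[C@H](CO)[C@@H](O)[C@H]1O`, by contrast, is measured with a number and gives 460 nM in this assay.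

Compounds 1 and 3 differ in one place, (thiophen-3-yl in place of 1-benzofuran-2-yl on an aromatic carbon), and that change brought an at least 43-fold lower number from compound 1 to compound 3 (1.63 log units; beyond the scatter). The size of this step rests on a limit, (the limit of > 20000 nM in this assay, at which 2 of the 3 values shown sit), so it is a lower bound for the true drop.

Compound 4 `Cc1nc(N)c2c(-c3ccsc3)cn([C@@H]3O[C@H](CO)[C@@H](O)[C@H]3O)c2n1`, not yet measured, carries the same change relative to compound 2, (thiophen-3-yl in place of 1-benzofuran-2-yl on an aromatic carbon); the place lines for the two changes agree word for word, so it is the same change. The difference between the two cores of compound 1 and compound 2 is not broken down here. Compound 4 is expected to show a step of similar size, an at least 20-fold lower number from compound 2 to compound 4 (1.30 log units; beyond the scatter), since the same change from compound 1 to compound 3 gave an at least 43-fold lower number from compound 1 to compound 3 (1.63 log units; beyond the scatter). For compound 4 the estimate in this assay is 1000 nM, with a likely range from 200 nM to 10000 nM.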

Compound 4, half-maximal inhibitory concentration: > 20000 nM
Compound 4: only a limit was reported (the forecaster's own chance of this, stated with the estimate: 25%); at least 20-fold (1.30 log units) between middle value and limit.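

Compound 2 and compound 4 both stand at a limit rather than a number in this assay, so the step between them cannot be read: the limit of > 20000 nM in this assay, at which 3 of the 4 values shown sit.

The compounds shown leave open whether thiophen-3-yl in place of 1-benzofuran-2-yl changes the number at all on the core of compound 2, as it did on the core of compound 1, and how far either compound lies past the limit.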